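The compounds below may be only part of what the source reports. "The series", "measured", "known", "first", "only" and "open" are said of these compounds alone.

Compound 1 `C[C@@H](c1ccc(Cl)cc1)N1Cc2cncn2C(C[C@@H](O)c2ccccc2)S1(=O)=O`: 234 nM
Compound 2 `CC(C)CC1n2cncc2CN([C@H](C)c2ccc(Cl)cc2)S1(=O)=O`: 204 nM

In an assay on cells for inhibition of cytochrome P450 11B1, mitochondrial (Homo sapiens) (a higher number here means a weaker inhibitor, a lower number a stronger inhibitor), compound 1 gives the higher of the two numbers shown, yet compound 2 with 204 nM lies within the scatter of it, so the two cannot be told apart. Compound 3 `COC(C)(C)CC1n2cncc2CN([C@@H](C)c2ccc(Cl)cc2)S1(=O)=O` differs from compound 1 by 1-methoxy-1-methylethyl in place of hydroxy(phenyl)methyl on a saturated chain carbon bound to a saturated ring carbon. Within the data shown here, no measured pair isolates this change, so the expectation rests on compound 1 alone, and no step beyond the scatter is expected in either direction. Compound 3 is expected to give 250 nM, within 80 nM to 800 nM. The expected step of a 1.1-fold higher number from compound 1 to compound 3 (0.03 log units; within the scatter) is small.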

Compound 3, half-maximal inhibitory concentration: 20.6 nM
Beside the measured number, compound 3's estimate is 12-fold (1.08 log units) above it, and the stated range ends above it.
By their numbers in this assay, from the lowest: compound 3; then compounds 2 and 1 (each within the scatter of the next).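

In this assay the step from 2-hydroxy-2-phenylethyl to 2-methoxy-2-methylpropyl gives an 11-fold lower number from compound 1 to compound 3 (1.06 log units; beyond the scatter) and so shows that this place on the core can move the number well beyond the scatter. The change removes the six-membered aromatic ring, the hydrogen-bond donor and the defined stereocentre of that group together, so the step cannot be assigned to any one of them. Nothing measured here gives a reason for the step.

Which of those parts matters stays open. So does whether an amine or a carboxylic acid at this place would hold the lower number.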